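Amide nitrogen substituents on a catechol-ether phosphodiesterase series

The source may report more compounds than this note shows. Statements on the series, on what has been measured and on what is new or still open speak of the compounds shown alone.

Compound 1: `COc1ccc(C(=O)Nc2ccccc2C)cc1OC1CCCC1`, 300 nM
Compound 2: `COc1ccc(C(=O)Nc2c(F)cnc(F)c2F)cc1OC1CCCC1`, 85 nM

For the measured compounds named here, in an assay on isolated protein for inhibition of phosphodiesterase 4A (Sus scrofa) (on this read-out lower numbers stand for stronger inhibition and higher numbers for weaker inhibition), compound 1 gives 300 nM, the highest of the two numbers so far. Its nearest neighbour, compound 2, gives 85 nM, a gap beyond the usual scatter. Compound 3, `COc1ccc(C(=O)Nc2c(C)nsc2Br)cc1OC1CCCC1`, has not yet been measured. It differs from compound 1 by 5-bromo-3-methyl-1,2-thiazol-4-yl in place of 2-methylphenyl on an amide-type nitrogen. Because compound 2 gives 85 nM with a heteroaromatic amide partner, a step toward stronger inhibition is expected from compound 1 to compound 3, estimated as a 2.3-fold lower number from compound 1 to compound 3 (0.36 log units; beyond the scatter). Compound 3 is therefore estimated at 130 nM, with a range from 40 nM to 450 nM.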

Compound 3, half-maximal inhibitory concentration: 500 nM
Compound 3: the middle estimate sits 3.8-fold (0.59 log units) below what was measured; measured number above the stated range.
By their numbers in this assay, from the lowest: compound 2; then compounds 1 and 3 (each within the scatter of the next).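

In this assay, putting 5-bromo-3-methyl-1,2-thiazol-4-yl in place of 2-methylphenyl on the amide-type nitrogen gives a 1.7-fold higher number from compound 1 to compound 3 (0.22 log units; within the scatter), so this position accepts a five-membered aromatic ring with 2 hetero atoms, with no gain. The lower number of compound 2, at 85 nM, therefore does not extend to every heteroaromatic partner. Nothing available explains this outcome. Still open, going by these compounds, is what the bromine in compound 3 contributes, which a chlorine or a plain hydrogen in its place would test.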